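A Methyl on the Pyrimidine Ring of a Sulfonamide Thiourea

The source may report more compounds than this note shows. Statements on the series, on what has been measured and on what is new or still open speak of the compounds shown alone.

Compound 1 `NS(=O)(=O)c1ccc(N/C(S)=N\c2ccnc3cc(C(F)(F)F)ccc23)cc1` carries a hydrogen on its sulfonamide nitrogen. In a functional assay on AS49-RAW cells (Homo sapiens) for antiproliferative activity, read by sulforhodamine B assay, with a stated time of 48 h (on this read-out higher numbers stand for weaker inhibition and lower numbers for stronger inhibition), compound 1 gives 36600 nM. Compound 2 `O=S(=O)(Nc1nccs1)c1ccc(N/C(S)=N\c2ccnc3cc(C(F)(F)F)ccc23)cc1` carries a 1,3-thiazol-2-yl on that nitrogen instead, and in this assay compound 2 gives 27200 nM. Compound 3 `O=S(=O)(Nc1ncccn1)c1ccc(N/C(S)=N\c2ccnc3cc(C(F)(F)F)ccc23)cc1` carries a pyrimidin-2-yl there, and in this assay compound 3 gives 37800 nM. All three numbers lie close together: the steps of a 1.3-fold lower number from compound 1 to compound 2 (0.13 log units; within the scatter), a 1.0-fold higher number from compound 1 to compound 3 (0.01 log units; within the scatter) and a 1.4-fold higher number from compound 2 to compound 3 (0.14 log units; within the scatter) are each within the usual scatter, so exchanging one group for another on the sulfonamide nitrogen has left the read-out essentially unchanged. Compound 3 thus stands among its neighbours rather than apart from them.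

Compound 4 `Cc1ccnc(NS(=O)(=O)c2ccc(N/C(S)=N\c3ccnc4cc(C(F)(F)F)ccc34)cc2)n1` differs from compound 3 in one place: methyl in place of hydrogen on an aromatic carbon. Among the compounds with values here, no measured step touches this ring; the nearest comparisons are the exchanges on the sulfonamide nitrogen, all of which stayed within the scatter. A single methyl added to a group whose wholesale replacement barely moved the number is expected to move it little, in no particular direction. The expected step is a 1.1-fold lower number from compound 3 to compound 4 (0.03 log units; within the scatter). Compound 4 is therefore estimated at 35000 nM, with a range from 15000 nM to 80000 nM.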

Compound 4, half-maximal inhibitory concentration: 31000 nM
Compound 4: the middle estimate sits 1.1-fold (0.05 log units) above what was measured; measured number inside the range.
By their numbers in this assay, from the lowest: compounds 2, 4, 1 and 3 (each within the scatter of the next).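

Placing a methyl on the pyrimidine ring, the first change here made on that ring rather than on the sulfonamide nitrogen, leaves the number in this assay within the scatter (a 1.2-fold lower number from compound 3 to compound 4 (0.09 log units; within the scatter)). The new 4-methylpyrimidin-2-yl group also stays level with the other substituents on that nitrogen (a 1.1-fold higher number from compound 2 to compound 4 (0.06 log units; within the scatter); a 1.2-fold lower number from compound 1 to compound 4 (0.07 log units; within the scatter)), so this aromatic carbon next to the ring nitrogen takes a methyl with no change that can be told from ordinary assay noise. No supporting measurement bears on what the methyl does to the molecule or on why the read-out holds steady.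

As far as these compounds go, one small group at one position says little about larger ones, so it remains open whether an amine, a carboxylic acid or a longer chain such as propyl on this carbon would also leave the number in place. All four compounds lie within the scatter of one another, which also leaves open what change, on this ring or elsewhere on the shared core, would move the read-out beyond that scatter at all.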